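The source may report more compounds than this note shows. Statements on the series, on what has been measured and on what is new or still open speak of the compounds shown alone.

Within the data shown here, in a functional assay on a cell-free system (Platelet, plasma, Homo sapiens) for inhibition (a lower number here means a stronger inhibitor, a higher number a weaker inhibitor), compound 3 `O=C(Nc1cccc(OCc2ccc(F)cc2)c1)C1CCNCC1` gives 68000 nM, the lowest number of the three measured so far. Compound 2 `O=C(Nc1cccc(OCc2ccccc2)c1)C1CCNCC1` gives 229000 nM, and compound 1 `N=C(N)N1CCCC(C(=O)Nc2cccc(OCc3ccc(-c4ccccc4)cc3)c2)C1` gives 1000000 nM. Compound 4 `O=C(Nc1cccc(OCc2ccc(-c3ccccc3)cc2)c1)C1CCNCC1` follows from compound 3 by one change, phenyl in place of fluoro on an aromatic carbon, para to a large group (phenyl in place of fluoro on an aromatic carbon).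

Among the measured compounds shown here, the only measured step at this place is a 3.4-fold lower number from compound 2 to compound 3 (0.53 log units; beyond the scatter), which is modest and beyond the scatter. It shows that a substituent here can lower the number, but it involves fluoro, not phenyl. Compound 1 also carries a phenyl at this place, but it differs from compound 4 elsewhere too, so it offers only a loose caution against expecting much.

In this assay, a small step leaning towards a lower number is therefore expected, estimated as a 1.7-fold lower number from compound 3 to compound 4 (0.23 log units; within the scatter). For compound 4 the estimated value is 40000 nM, with an expected range from 6000 nM to 250000 nM.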

Compound 4, half-maximal inhibitory concentration: 111000 nM
Beside the measured number, compound 4's estimate is 2.8-fold (0.44 log units) below it; low and high end bracket the measured number.
By their numbers in this assay, from the lowest: compounds 3 and 4 (each within the scatter of the next); then compound 2; then compound 1.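

In this assay phenyl in place of fluoro on this aromatic carbon gives a 1.6-fold higher number from compound 3 to compound 4 (0.21 log units; within the scatter) and so does not separate the two groups. Against hydrogen, phenyl gives a 2.1-fold lower number from compound 2 to compound 4 (0.31 log units; beyond the scatter) and thus joins fluoro as a second group at this place that goes with a lower number than hydrogen. With phenyl kept, the exchange on the carbonyl carbon gives a 9.0-fold lower number from compound 1 to compound 4 (0.95 log units; beyond the scatter) and thus places the high number of compound 1 with that group rather than with phenyl.

From the compounds shown here alone, whether a methoxy group, an amine or a carboxylic acid at this place would read differently from fluoro and phenyl stays open. Nothing measured on these compounds says why fluoro and phenyl read alike here.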